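A few compounds are considered here, and "the series" means these few. Any claim that something is new, unique, unknown or untested is made for them only; others in the source may bear on it.

For the measured compounds named here, in a functional assay (aorta) for inhibition, with Oryctolagus cuniculus as the target (on this read-out higher numbers stand for weaker binding and lower numbers for tighter binding), three related compounds have numbers so far. Compound 1 (`CCOC(=O)/C=C1\C2C3C=CC(CCC3)C2C(=O)N1Cc1ccc(-c2ccccc2-c2nn[nH]n2)cc1`) gives 39.8 nM, compound 2 (`CCOC(=O)/C=C1\N(Cc2ccc(-c3ccccc3-c3nn[nH]n3)cc2)C(=O)CC12CCCC2`) gives 3.16 nM, and compound 3 (`CCOC(=O)/C=C1\N(Cc2ccc(-c3ccccc3-c3nn[nH]n3)cc2)C(=O)CC1(C)CC`) gives 25.1 nM. Compound 3 thus lies within the scatter of compound 1, while its gap to compound 2 is beyond the scatter.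

Compound 4 (`CCOC(=O)/C=C1/C(C)CC(=O)N1Cc1ccc(-c2ccccc2-c2nn[nH]n2)cc1`) departs from compound 3 at a single place, with hydrogen in place of ethyl on a saturated ring carbon. Going by the values given here, no two measured compounds differ in only one place, so no direct precedent exists for this change. The guidance is indirect: compound 3 gives 25.1 nM, whereas compound 2, with more carbon on that same ring carbon, gives 3.16 nM. Compound 1 does not test this loose trend, and two compounds cannot establish it. A moderate move toward a higher number, meaning weaker binding, therefore seems more likely than a move the other way, although a result within the scatter would not be surprising. The expected change is a 2.4-fold higher number from compound 3 to compound 4 (0.38 log units; beyond the scatter). For compound 4 the estimated value is 60 nM, with an expected range from 15 nM to 240 nM.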

Compound 4, dissociation constant: 316 nM
Estimate against measurement, compound 4: 5.3-fold (0.72 log units) below; measured number above the stated range.
By their numbers in this assay, from the lowest: compound 2; then compounds 3 and 1 (each within the scatter of the next); then compound 4.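

In this assay, for the compounds shown here, putting hydrogen in place of ethyl on a saturated ring carbon of the five-membered non-aromatic ring gives a 13-fold higher number from compound 3 to compound 4 (1.10 log units; beyond the scatter) as the first step that can be read directly at this position. The change removes only the two carbon atoms of the ethyl group, adds no ring, and leaves the counts of hydrogen-bond donors, hydrogen-bond acceptors and net charge untouched, yet the step is large and well beyond the scatter, so this ring carbon is clearly sensitive to what it carries. Nothing available here explains why so small a change in atoms goes with so large a change in the number.

The compounds shown leave open whether this sensitivity belongs to the ethyl group in particular or to any carbon chain at this ring carbon, which a longer propyl chain, a hydroxymethyl group or an amine in the same place could begin to separate. They also leave open whether the same replacement would give a step of similar size on the core of compound 1 or compound 2.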